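Swapping the acyl-urea aryl group in a thiazole-hydrazone series

The compounds below may be only part of what the source reports. "The series", "measured", "known", "first", "only" and "open" are said of these compounds alone.

Of the compounds shown here, three have been measured so far in a functional assay on A549 cells (Homo sapiens) for inhibition, read by MTT assay, with a stated time of 72 h; a lower number here means a stronger inhibitor, a higher number a weaker inhibitor. Compound 1 `CN(C(=O)NC(=O)c1cccc(C(F)(F)F)c1)c1nc(C(F)(F)F)c(C(=O)N/N=C/c2ccc(C(F)(F)F)cc2)s1` gives 6.2 ug/mL, compound 2 `CN(C(=O)NC(=O)c1cccc(C(F)(F)F)c1)c1nc(C(F)(F)F)c(C(=O)N/N=C/c2ccccc2C(F)(F)F)s1` gives 12.1 ug/mL, and compound 3 `CN(C(=O)NC(=O)c1ccc(C(F)(F)F)cc1)c1nc(C(F)(F)F)c(C(=O)N/N=C/c2cc(C(F)(F)F)cc(C(F)(F)F)c2)s1` gives 5.9 ug/mL. Compound 2 therefore has the highest number of the three, though its gap to compound 1 is within the scatter, as the step of a 2.0-fold higher number from compound 1 to compound 2 (0.29 log units; within the scatter) shows. Compound 4 `CN(C(=O)NC(=O)c1ccccc1F)c1nc(C(F)(F)F)c(C(=O)N/N=C/c2ccccc2C(F)(F)F)s1` differs from compound 2 by 2-fluorophenyl in place of 3-(trifluoromethyl)phenyl on a carbonyl carbon. Going by the values given here, no measured step touches this position: the only single-point step, from compound 1 to compound 2, changes the aryl on the hydrazone carbon, and compound 3 differs from compound 2 at two places at once. With no guide, no change beyond the scatter is expected, so compound 4 is estimated at 12 ug/mL (range 5 ug/mL to 28 ug/mL), a step of a 1.0-fold lower number from compound 2 to compound 4 (0.00 log units; within the scatter) in this assay.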

Compound 4, half-maximal inhibitory concentration: 6.32 ug/mL
Beside the measured number, compound 4's estimate is 1.9-fold (0.28 log units) above it, and the stated range covers the measured number.
By their numbers in this assay, from the lowest: compounds 3, 1, 4 and 2 (each within the scatter of the next, the first and the last beyond it).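

Going by these compounds alone, this step is the first reading of the aryl group on the carbonyl carbon: 2-fluorophenyl in place of 3-(trifluoromethyl)phenyl gives a 1.9-fold lower number from compound 2 to compound 4 (0.28 log units; within the scatter) in this assay. This position therefore accepts a group with fewer heavy atoms and no trifluoromethyl without a change beyond the scatter. No evidence here bears on why. Going by these compounds, whether an amine or a short alkyl chain could stand in place of this aryl group stays open. Also open, on these data alone, is whether 2-fluorophenyl behaves alike with 4-(trifluoromethyl)phenyl on the hydrazone carbon.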